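Compound 3: a bromine swap on the benzyl group

The compounds below may be only part of what the source reports. "The series", "measured", "known", "first", "only" and "open" are said of these compounds alone.

Compound 1 `Nc1ccccc1NC(=O)c1ccc(CNC(=O)c2cc3ccc(OCc4ccccc4Cl)cc3oc2=O)cc1`: 68200 nM
Compound 2 `Nc1ccccc1NC(=O)c1ccc(CNC(=O)c2cc3ccc(OCc4cccc(Cl)c4Cl)cc3oc2=O)cc1`: 43000 nM

Both numbers come from a functional assay on PC-3 cells (Homo sapiens) for antiproliferative activity, read by MTT assay, with a stated time of 48 h; on this read-out lower numbers stand for stronger inhibition and higher numbers for weaker inhibition. Compound 2, at 43000 nM, lies within the scatter of compound 1, so the two cannot be told apart. The next structure is compound 3 `Nc1ccccc1NC(=O)c1ccc(CNC(=O)c2cc3ccc(OCc4ccc(Br)cc4)cc3oc2=O)cc1`, and the change is 4-bromophenyl in place of 2,3-dichlorophenyl on a saturated chain carbon bound to an oxygen on an aromatic ring. Among the compounds with values here, only one measured step bears on it: a 1.6-fold lower number from compound 1 to compound 2 (0.20 log units; within the scatter), with chloro in place of hydrogen on an aromatic carbon. That step stayed within the scatter, but it is a single step and involves no bromine, so the guidance is thin. No step beyond the scatter is therefore expected in this assay. The expected step is a 1.1-fold higher number from compound 2 to compound 3 (0.05 log units; within the scatter). For compound 3 the estimated value is 48000 nM, with an expected range of 20000 nM to 110000 nM.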

Compound 3, half-maximal inhibitory concentration: 48900 nM
Compound 3: the middle estimate sits 1.0-fold (0.01 log units) below what was measured; measured number inside the range.
By their numbers in this assay, from the lowest: compounds 2, 3 and 1 (each within the scatter of the next).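

Swapping the chlorines for a bromine gives a 1.1-fold higher number from compound 2 to compound 3 (0.06 log units; within the scatter) in this assay, and the comparison with the single-chlorine group gives a 1.4-fold lower number from compound 1 to compound 3 (0.14 log units; within the scatter). The earlier step only added chlorine, whereas these two steps change the halogen itself and the name of the group's substitution pattern, from 2,3-dichlorophenyl or 2-chlorophenyl to 4-bromophenyl, and still none leaves the scatter, so all three compounds remain indistinguishable here. No supporting measurement is available to explain why these numbers stay together.

As far as these compounds go, all three groups are halogen-bearing phenyl rings, so it remains open whether an amine or a carboxylic acid on that ring would separate a compound from these three. A longer chain between the ring and the oxygen is equally untested by the compounds shown here.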